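Changing the Carbamate Group: From Compound 2 to Compound 3

This account rests on a few compounds, and the source may have more. Where it says the series, first, only, none or still open, it means among the compounds named here.

Compound 1, `CC(C)(C)OC(=O)N1CCC(Oc2ncnc3c2CCN3c2ccc(S(C)(=O)=O)cc2F)CC1`: 139%
Compound 2, `CS(=O)(=O)c1ccc(N2CCc3c(OC4CCN(C(=O)OCCF)CC4)ncnc32)c(F)c1`: 86%

Of the compounds shown here, two have been measured in a functional assay on CHO-K1 cells with Glucose-dependent insulinotropic receptor (Homo sapiens) as the target, read by a luciferase reporter, with a stated time of 5 h (a lower number here means a smaller maximal response, a higher number a larger maximal response), and compound 2 stands lowest of the two: the single measured step, a number 53 percentage points lower from compound 1 to compound 2 (beyond the scatter), shows a large fall in the largest response when 2-fluoroethyl replaces tert-butyl on the oxygen of the carbamate. Compound 3, `CC(C)SC(=O)N1CCC(Oc2ncnc3c2CCN3c2ccc(S(C)(=O)=O)cc2F)CC1`, is the next compound. Its difference from compound 2 is isopropylsulfanyl in place of 2-fluoroethoxy on a carbonyl carbon. Going by the values given here, the only step that bears on this change is a number 53 percentage points lower from compound 1 to compound 2 (beyond the scatter), which shows that the group on this carbonyl carbon can move the largest response strongly. Since the 2-fluoroethoxy group that brought the fall now leaves, the expected step is a rise, a number 26 percentage points higher from compound 2 to compound 3 (beyond the scatter), with little certainty about its size. For compound 3 the estimated largest response in this assay is 112%, expected to lie between 80% and 145%.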

Compound 3, largest response reached (reported as percent of maximum), in percent of the reference or control that the assay uses: 138%
Beside the measured number, compound 3's estimate is 26 percentage points below it, within the range that was stated.
By their numbers in this assay, from the lowest: compound 2; then compounds 3 and 1 (each within the scatter of the next).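

In this assay the step of a number 52 percentage points higher from compound 2 to compound 3 (beyond the scatter) shows that the low response of compound 2 does not extend to every group on this carbonyl carbon: isopropylsulfanyl gives a large response where 2-fluoroethoxy does not. The step of a number 1 percentage points lower from compound 1 to compound 3 (within the scatter) puts isopropylsulfanyl on a par with tert-butoxy, so a carbonyl carbon bearing sulfur rather than oxygen can still reach the response of compound 1, and of these three compounds only compound 2 stands apart. No measurement given here explains why these groups differ. 

The compounds shown leave open whether the low response of compound 2 goes with the fluorine or with the unbranched chain, which a plain ethoxy group would help to separate. They also leave open how much sulfur itself matters, a question that an isopropoxy group would address directly.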